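The source may report more compounds than this note shows. Statements on the series, on what has been measured and on what is new or still open speak of the compounds shown alone.

Compound 2, `Cc1nc2ccc(C#CC(C)(O)CC3CC3)cc2n1-c1ncnc(N)n1`, was tested in an assay for binding affinity to serine/threonine-protein kinase PAK 1 (Homo sapiens), read by FRET and Z'-LYTE, with stated times of 10 min and 60 min; on this read-out lower numbers stand for stronger inhibition and higher numbers for weaker inhibition. In this assay compound 2 gives > 4500 nM, which is a limit of the assay rather than a number. The nearest measured neighbour is compound 1, `Cc1nc2ccc(C#CC(C)(O)CO)cc2n1-c1ncnc(N)n1`, which carries a hydroxy group where compound 2 carries a cyclopropyl group. In this assay compound 1 gives > 4500 nM, again a limit. Among the measured compounds shown here, the one measured step, a step that the two limits leave unreadable from compound 1 to compound 2, therefore cannot be read in size or direction, since both values sit at the limit of > 4500 nM in this assay, at which 2 of the 2 values shown sit.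

Compound 3, `Cc1nc2ccc(C#C[C@@](C)(O)c3nccs3)cc2n1-c1ncnc(N)n1`, has not yet been measured. It differs from compound 2 in one place: a group of 8 heavy atoms (5 carbon, 1 nitrogen, 1 oxygen, 1 sulfur; one five-membered aromatic ring with 2 hetero atoms) in place of a group of 7 heavy atoms (6 carbon, 1 oxygen; one three-membered non-aromatic ring of carbon only), on a triple-bonded carbon. For the measured compounds named here, the only measured step is the unreadable one from compound 1 to compound 2, so no measured step speaks to how large a change to expect in this assay for compound 3, nor in which direction. With nothing to point elsewhere, compound 3 is expected to remain close to where the measured compounds sit, and its estimated value is 4000 nM, with a range from 1000 nM to 20000 nM. That estimate corresponds to an expected step of an at least 1.1-fold lower number from compound 2 to compound 3 (0.05 log units; that floor lies within the scatter).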

Compound 3, inhibition constant: > 4500 nM
Compound 3 ended at the assay's limit; the forecaster's own chance of this, stated with the estimate: 60%; middle value at least 1.1-fold (0.05 log units) away from the limit.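

Compound 3 also ends at a limit in this assay, so its steps from compound 1 and from compound 2 cannot be read in size or direction: the limit of > 4500 nM in this assay, at which 3 of the 3 values shown sit.

The compounds shown leave open how strongly any of the three actually binds, and whether changing the group on the triple-bonded carbon makes any difference.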